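Chloro Substitution in Two Series Tested for Cytotoxicity

The source may report more compounds than this note shows. Statements on the series, on what has been measured and on what is new or still open speak of the compounds shown alone.

Measured compounds:
compound 1, `C=C[C@@](C)(/C=C/c1ccc(OCC(=O)Nc2ccccc2)cc1)CCC=C(C)C`, 63300 nM
compound 2, `C=C[C@@](C)(/C=C/c1ccc(OCC(=O)Nc2ccc(Cl)cc2)cc1)CCC=C(C)C`, 50700 nM
compound 3, `C=C[C@@](C)(/C=C/c1ccc(OC(=O)c2cn(-c3ccccc3)nn2)cc1)CCC=C(C)C`, 69900 nM

In a toxicity assay on RAW264.7 cells (Mus musculus) for cytotoxicity, read by MTT assay, with a stated time of 24 h (a lower number here means a stronger inhibitor, a higher number a weaker inhibitor), compound 1 gives 63300 nM and compound 2 gives 50700 nM. The two differ by chloro in place of hydrogen on an aromatic carbon, and the step is a 1.2-fold lower number from compound 1 to compound 2 (0.10 log units; within the scatter). Compound 3 rests on a different core; how its core differs from that of compound 1 is not broken down here. In this assay compound 3 gives 69900 nM. Compound 4, `C=C[C@@](C)(/C=C/c1ccc(OC(=O)c2cn(-c3ccc(Cl)cc3)nn2)cc1)CCC=C(C)C`, differs from compound 3 by chloro in place of hydrogen on an aromatic carbon, the same change as that from compound 1 to compound 2. Because the earlier step was a 1.2-fold lower number from compound 1 to compound 2 (0.10 log units; within the scatter), the step from compound 3 to compound 4 is expected to be small, a 1.2-fold lower number from compound 3 to compound 4 (0.07 log units; within the scatter). Compound 4 is therefore estimated at 60000 nM, between 30000 nM and 120000 nM.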

Compound 4, half-maximal inhibitory concentration: 115000 nM
Estimate against measurement, compound 4: 1.9-fold (0.28 log units) below; the range from low to high includes it.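

In this assay, chloro in place of hydrogen on the second core gives a 1.6-fold higher number from compound 3 to compound 4 (0.22 log units; within the scatter). Set beside the earlier step, the two cores do not separate: the same change on two cores in this assay, a 1.2-fold lower number (0.10 log units; within the scatter) from compound 1 to compound 2 and a 1.6-fold higher number (0.22 log units; within the scatter) from compound 3 to compound 4, 2.1-fold (0.31 log units) apart, within the scatter of two such steps. The change thus carries from one core to the other with no difference that stands clear of the scatter, but each step also lies within the scatter, so the data show no clear shift from chloro on either core and say nothing about any further core.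

The compounds shown leave open whether another group at that place on the ring, such as fluoro, methoxy or an amine, would move the number beyond the scatter. They also leave open whether a carboxylic acid there would behave alike on both cores.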